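Swapping One Halogen-Bearing Phenyl for Another

The compounds below may be only part of what the source reports. "The series", "measured", "known", "first", "only" and "open" are said of these compounds alone.

Of the compounds shown here, three sharing one core have been tested in a functional assay on the whole organism (strain Wistar albino) for inhibition, with Rattus norvegicus as the target, read by paw edema, with stated times of 30 min and 3 h, at a dose of 20 mg/kg by the oral route; a higher number here means more inhibition at the dose given (going by the name of the read-out), a lower number less inhibition. Compound 1 `CCc1nn2c(C(C)c3ccc(CC(C)C)cc3)nnc2s1` gives 55%, compound 2 `CCCc1nn2c(C(C)c3ccc(CC(C)C)cc3)nnc2s1` gives 34%, and compound 3 `CC(C)Cc1ccc(C(C)c2nnc3sc(-c4ccc(Br)cc4)nn23)cc1` gives 67%, the highest of the three. The measured steps show the weight of the group on the five-membered ring: a number 12 percentage points higher from compound 1 to compound 3 (beyond the scatter) and a number 33 percentage points higher from compound 2 to compound 3 (beyond the scatter), both beyond the scatter, while a number 21 percentage points lower from compound 1 to compound 2 (beyond the scatter) is modest. Compound 4 `CC(C)Cc1ccc(C(C)c2nnc3sc(-c4ccccc4Cl)nn23)cc1` differs from compound 3 by 2-chlorophenyl in place of 4-bromophenyl on an aromatic carbon. Within the data shown here, no measured step compares one substituted phenyl with another, so the only guide is that the number for the phenyl-bearing compound 3 is higher than the numbers for the small chains. Compound 4 is therefore expected to stay close, with a number 7 percentage points lower from compound 3 to compound 4 (within the scatter) near the scatter. For compound 4 the estimated value is 60%, with a range from 45% to 75%.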

Compound 4, a percentage reported as inhibition, in the whole organism at one dose (the size of the read-out at that dose, not a potency): 59%
Beside the measured number, compound 4's estimate is 1 percentage points above it; low and high end bracket the measured number.
By their numbers in this assay, from the lowest: compound 2; then compounds 1, 4 and 3 (each within the scatter of the next, the first and the last beyond it).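

Trading 4-bromophenyl for 2-chlorophenyl at this position in this assay gives a number 8 percentage points lower from compound 3 to compound 4 (within the scatter) and so no readable difference. Against the chains the result splits: a number 25 percentage points higher from compound 2 to compound 4 (beyond the scatter) with propyl replaced, yet a number 4 percentage points higher from compound 1 to compound 4 (within the scatter) with ethyl replaced, so 2-chlorophenyl is not set apart from every small chain. Nothing available explains these numbers. The halogen and its place on the phenyl change together between compound 3 and compound 4, leaving the two effects unseparated. Going by these compounds, how a plain phenyl, or a phenyl carrying an amine or a carboxylic acid, would read here also stays open.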